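The compounds below may be only part of what the source reports. "The series", "measured", "known", "first", "only" and "open" are said of these compounds alone.

Compound 1 `S=C(N/N=C/c1ccc(Oc2ccc(Cl)cc2)cc1)Nc1ccccc1` gives, in a physicochemical assay for lipophilicity, in phosphate buffer, measured as octanol-water partition, with a stated time of 24 h (on this read-out lower numbers stand for lower lipophilicity and higher numbers for higher lipophilicity), a value of 5.52. Within the data shown here, compound 2 `O=[N+]([O-])c1ccc(Oc2ccc(/C=N/NC(=S)Nc3ccccc3)cc2)cc1` gives in this assay a value of 4.95, the lowest of the two numbers measured, and the only measured step, a number 0.57 log units lower from compound 1 to compound 2 (beyond the scatter), lies beyond the scatter.

Compound 3 `Fc1ccc(Oc2ccc(/C=N/NC(=S)Nc3ccccc3)cc2)cc1` has not yet been measured. It differs from compound 2 in one place: fluoro in place of nitro on an aromatic carbon. The step that bears on this change is a number 0.57 log units lower from compound 1 to compound 2 (beyond the scatter), where nitro replaced chloro at the same place; the step from nitro to fluoro goes the other way in kind, though chloro and fluoro are not the same group, so a full return to the number of compound 1 need not follow. The expectation for compound 3 in this assay is therefore a rise of modest size, a number 0.30 log units higher from compound 2 to compound 3 (within the scatter). Compound 3 is accordingly estimated at 5.25, between 4.9 and 5.6.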

Compound 3, partition coefficient: 5.09
Compound 3: the middle estimate sits 0.16 log units above what was measured; the range from low to high includes it.
By their numbers in this assay, from the lowest: compounds 2 and 3 (each within the scatter of the next); then compound 1.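

In this assay, fluoro in place of nitro, on an aromatic carbon para to a large group, gives a number 0.14 log units higher from compound 2 to compound 3 (within the scatter), so a group of 3 heavy atoms with 2 hydrogen-bond acceptors and a single fluorine atom with none are not told apart at this position. Fluoro in place of chloro gives a number 0.43 log units lower from compound 1 to compound 3 (beyond the scatter), which shows that the two halogens do not read alike here and that, of the three groups, chloro alone stands apart from the other two. Nothing available explains these numbers.

As far as these compounds go, what an amine, a carboxylic acid or a longer chain such as butoxy would give at this position remains open. So does whether the gap between chloro and fluoro would hold at any other place on the shared core.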